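The source may report more compounds than this note shows. Statements on the series, on what has been measured and on what is new or still open speak of the compounds shown alone.

Measured so far:
Compound 1 `O=S(=O)(NCCCNCc1ccccc1Cl)c1cc(C(F)(F)F)cc(C(F)(F)F)c1` in a functional assay on HT-29 cells (Homo sapiens) for inhibition, read by MTT assay, with a stated time of 72 h; on this read-out lower numbers stand for stronger inhibition of growth and higher numbers for weaker inhibition of growth: 20000 nM
Compound 2 `O=S(=O)(NCCCCNCc1ccc(Br)cc1)c1cc(C(F)(F)F)cc(C(F)(F)F)c1` in this assay: 1600 nM

Compound 2 holds the lowest number of the two; its nearest neighbour is compound 1, reached by a 13-fold lower number from compound 1 to compound 2 (1.10 log units; beyond the scatter). Compound 3 `O=S(=O)(NCCCNCc1ccc(Cl)c(Cl)c1)c1cc(C(F)(F)F)cc(C(F)(F)F)c1` differs from compound 2 by (3,4-dichlorobenzyl)amino in place of ((4-bromobenzyl)amino)methyl on a saturated chain carbon, three bonds along the chain from a sulfonamide nitrogen. For the measured compounds named here, only that one step bears on this change, and it alters more than one part of the structure at once, so its size is a loose guide. Compound 3 keeps a shorter chain like compound 1 while retaining a halogenated benzyl group, so a moderate rise in the number is expected: a 2.5-fold higher number from compound 2 to compound 3 (0.40 log units; beyond the scatter). The estimate for compound 3 is 4000 nM, within 1500 nM to 12000 nM.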

Compound 3, concentration for 50% growth inhibition: 4700 nM
The estimate for compound 3 lay 1.2-fold (0.07 log units) below the measured number; the range from low to high includes it.
By their numbers in this assay, from the lowest: compound 2; then compound 3; then compound 1.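

In this assay the change from 2-chlorophenyl to 3,4-dichlorophenyl on an unchanged chain gives a 4.3-fold lower number from compound 1 to compound 3 (0.63 log units; beyond the scatter) and so shows that the ring substitution alone moves the number. The other step, a 2.9-fold higher number from compound 2 to compound 3 (0.47 log units; beyond the scatter), changes chain and ring together and cannot be divided between them. Still open, as far as these compounds go, is whether 4-bromophenyl on the chain of compound 3 would match compound 2. Also open, from the compounds shown here alone, is how a longer chain, or an amide in place of the amine, would fare. Nothing at hand gives a cause for either step.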